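Two Trimethoxyphenyl Triazolothiadiazines Against Lung Cancer Cells

This account rests on a few compounds, and the source may have more. Where it says the series, first, only, none or still open, it means among the compounds named here.

Measured so far:
compound 1, `COc1cc(-c2nnc3n2NC(c2cccs2)C(C(=O)c2ccc(F)cc2)S3)cc(OC)c1OC`: 45000 nM
compound 2, `COc1cc(-c2nnc3n2NC(c2ccco2)C(C(=O)c2ccc(C)cc2)S3)cc(OC)c1OC`: > 100000 nM

Both compounds were tested in a functional assay on A549 cells (Homo sapiens) for cytotoxicity, read by MTT assay, with a stated time of 48 h; on this read-out lower numbers stand for stronger inhibition and higher numbers for weaker inhibition. Compound 1 gives a number in this assay, 45000 nM. Compound 2 gives no number in this assay but only a limit, > 100000 nM. That limit is the edge of what the test can report, and one of the two values sits there (the limit of > 100000 nM in this assay, at which 1 of the 2 values shown sits).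

Compound 3, `COc1cc(C(=O)C2Sc3nnc(-c4cc(OC)c(OC)c(OC)c4)n3NC2c2ccco2)cc(OC)c1OC`, is not yet measured. Its difference from compound 2 is one group: 3,4,5-trimethoxyphenyl in place of 4-methylphenyl on a carbonyl carbon.

Compound 2 stands at the limit, so any change that brings compound 3 into the measurable range would be a step downward in this assay. The expected step of an at least 1.6-fold lower number from compound 2 to compound 3 (0.22 log units; that floor lies within the scatter) is a modest gain, not far beyond the usual scatter. For compound 3 the expected value in this assay is 60000 nM, with a range from 12000 nM to 200000 nM.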

Compound 3, half-maximal inhibitory concentration: 48300 nM
Compound 3: the middle estimate sits 1.2-fold (0.09 log units) above what was measured; measured number inside the range.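

The two earlier compounds differ in more than one place, so they could not tie any change in this assay to a single group. Here only the group on the carbonyl carbon changes, with 3,4,5-trimethoxyphenyl in place of 4-methylphenyl, giving an at least 2.0-fold lower number from compound 2 to compound 3 (0.31 log units; beyond the scatter) and showing that this position can bring a compound from the limit into the measurable range. Compound 2 has only a limit rather than a number, so the step has a floor but no known full size: the limit of > 100000 nM in this assay, at which 1 of the 3 values shown sits.

As far as these compounds go, it remains open whether all of the methoxy groups are needed, or whether an amine or a carboxylic acid on the same ring would serve as well. From the compounds shown here alone, it is also open whether the same change would give a similar step on compound 1, which differs from compound 2 in more than one place.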